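The compounds below may be only part of what the source reports. "The series", "measured", "known", "first", "only" and "open" are said of these compounds alone.

Measured so far:
compound 1, `COc1ccc(-c2cn(C)c(NC(=O)c3ccc(F)cc3)n2)cc1`: in a toxicity assay on THP-1 cells (Homo sapiens) for inhibition (a higher number here means that more compound is tolerated, a lower number that less compound is tolerated), compound 1 gives > 50000 nM, a limit of the assay.
compound 2, `COc1ccc(-c2cnc(NC(=O)c3cnco3)n2C)cc1`: in this assay compound 2 gives > 100000 nM, also a limit of the assay.

For the measured compounds named here, compound 2 thus stands at a limit, and the other value shown is a limit as well (the limit of > 100000 nM in this assay, at which 1 of the 2 values shown sits, (the limit of > 50000 nM in this assay, at which 1 of the 2 values shown sits)), so no step between measured compounds can be sized here. Compound 3 `COc1ccc(-c2cnc(NC(=O)C3CCCC3)n2C)cc1` differs from compound 2 by cyclopentyl in place of 1,3-oxazol-5-yl on a carbonyl carbon. Going by the values given here, with no measured step to lean on, the expected step of a number no higher from compound 2 to compound 3 (the limit leaves the size open) is none beyond the scatter. For compound 3 the estimate in this assay is 100000 nM, range 30000 nM to 300000 nM, most likely again reported only as a limit.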

Compound 3, half-maximal cytotoxic concentration: > 100000 nM
Compound 3: a limit, no number (the forecaster's own chance of this, stated with the estimate: 75%); the middle value lies on the limit itself.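

No step can be read from compound 2 to compound 3, because both are reported only as limits: the limit of > 100000 nM in this assay, at which 2 of the 3 values shown sit.

The compounds shown leave open at what concentration any of them stops being tolerated, and whether cyclopentyl in place of 1,3-oxazol-5-yl shifts that concentration.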